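Swapping a fluorophenyl for a fluoropyridyl on the piperazine

The compounds below may be only part of what the source reports. "The series", "measured", "known", "first", "only" and "open" are said of these compounds alone.

Of the compounds shown here, three with a shared core have been measured in an assay for displacement of a labelled ligand from Adrenergic receptor alpha-1 (Homo sapiens); on this read-out lower numbers stand for stronger inhibition and higher numbers for weaker inhibition. Compound 1 `Cn1c(=O)cnn(CCCCN2CCN(c3ccccc3C#N)CC2)c1=O` gives 7.3 nM. Compound 2 `Cn1c(=O)cnn(CCCCN2CCN(c3c(Br)cccc3C#N)CC2)c1=O`, which carries an added bromo group, gives 450 nM, and the step of a 62-fold higher number from compound 1 to compound 2 (1.79 log units; beyond the scatter) is a large loss. Compound 3 `Cn1c(=O)cnn(CCCCN2CCN(c3ccccc3F)CC2)c1=O` gives 9.73 nM; it stands second highest of the three numbers, close to compound 1 through the step of a 1.3-fold higher number from compound 1 to compound 3 (0.12 log units; within the scatter), and far from compound 2 through the step of a 46-fold lower number from compound 2 to compound 3 (1.67 log units; beyond the scatter).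

Compound 4 `Cn1c(=O)cnn(CCCCN2CCN(c3ccc(F)cn3)CC2)c1=O` differs from compound 3 by 5-fluoropyridin-2-yl in place of 2-fluorophenyl on an amine nitrogen in a ring. Among the measured compounds shown here, no measured step exchanges a ring carbon for a ring nitrogen, so none bears on this change directly. The step from compound 1 to compound 3 shows that changing the small group on the aryl ring scarcely moves the number, while the step from compound 1 to compound 2 shows that a larger alteration of that ring can cost a great deal. The expected step is a 2.6-fold higher number from compound 3 to compound 4 (0.41 log units; beyond the scatter), a modest weakening. Compound 4 is therefore estimated at 25 nM, within a range from 6 nM to 100 nM.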

Compound 4, inhibition constant: > 10000 nM
Compound 4 was reported as a limit; the forecaster's own chance of this, stated with the estimate: 2%; middle value at least 400-fold (2.60 log units) away from the limit.
By their numbers in this assay, from the lowest: compounds 1 and 3 (each within the scatter of the next); then compound 2. At a limit, above all of these: compound 4.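

In this assay compound 4 gives > 10000 nM as a limit of the assay, not a number. Nitrile and fluoro on the aryl ring had given values within the scatter of each other, yet 5-fluoropyridin-2-yl on the amine nitrogen gives an at least 1000-fold higher number from compound 3 to compound 4 (3.01 log units; beyond the scatter) and an at least 1300-fold higher number from compound 1 to compound 4 (3.13 log units; beyond the scatter) against those two groups. Even the 2-bromo-6-cyanophenyl group, the largest loss seen before, stays ahead, with an at least 22-fold higher number from compound 2 to compound 4 (1.34 log units; beyond the scatter) on going to this new ring, so the aryl group here tolerates far less than the earlier compounds suggested.

This one exchange both puts a nitrogen into the aromatic ring and moves the fluoro. With neither a 4-fluorophenyl nor an unsubstituted pyridin-2-yl group among the compounds shown, it stays open which of the two goes with the loss.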